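Pyrrolidine for methylpiperazine on the chromone side chain

The source may report more compounds than this note shows. Statements on the series, on what has been measured and on what is new or still open speak of the compounds shown alone.

Measured so far:
compound 1 `O=c1cc(-c2ccccc2)oc2cc(OCc3ccccc3)c(OCCCN3CCCC3)c(O)c12` — 1400 nM in a functional assay on A549 cells (Homo sapiens) for antiproliferative activity, read by MTT assay, with a stated time of 48 h; on this read-out lower numbers stand for stronger inhibition and higher numbers for weaker inhibition
compound 2 `CN1CCN(CCCCOc2c(O)cc3oc(-c4ccccc4)cc(=O)c3c2O)CC1` — > 100000 nM in this assay
compound 3 `CN1CCN(CCCOc2c(OCc3ccccc3)cc3oc(-c4ccccc4)cc(=O)c3c2O)CC1` — 1300 nM in this assay

Compound 3 and compound 1 share a core and differ only by pyrrolidin-1-yl in place of 4-methylpiperazin-1-yl on a saturated chain carbon, three bonds along the chain from an oxygen on an aromatic ring; the measured step is a 1.1-fold higher number from compound 3 to compound 1 (0.03 log units; within the scatter). Compound 2 gives only a limit of this assay, the one at the limit of > 100000 nM in this assay, at which 1 of the 3 values shown sits, so its value is not a number. How the core of compound 2 differs from the core of compound 3 is not broken down here.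

Compound 4 `O=c1cc(-c2ccccc2)oc2cc(O)c(OCCCCN3CCCC3)c(O)c12` is not yet measured. It stands to compound 2 as compound 1 stands to compound 3, by pyrrolidin-1-yl in place of 4-methylpiperazin-1-yl on a saturated chain carbon, four bonds along the chain from an oxygen on an aromatic ring. The place differs: four bonds along the chain from an oxygen on an aromatic ring rather than three, so this is the same kind of change, not the same change.

The expected step is an at least 1.2-fold lower number from compound 2 to compound 4 (0.09 log units; that floor lies within the scatter), resting on the measured step of a 1.1-fold higher number from compound 3 to compound 1 (0.03 log units; within the scatter) being within the scatter. Compound 4 is therefore estimated at 80000 nM in this assay, with an expected range from 15000 nM to 300000 nM, and a fair chance that only a limit is reported.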

Compound 4, half-maximal inhibitory concentration: 51000 nM
For compound 4 the middle estimate is 1.6-fold (0.20 log units) above the measured one, within the range that was stated.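

The value of compound 2, > 100000 nM, is a limit and not a number. In this assay, pyrrolidin-1-yl in place of 4-methylpiperazin-1-yl on this second core can therefore be read only as an at least 1.9-fold lower number from compound 2 to compound 4 (0.29 log units; that floor lies within the scatter), which shows no more than a floor for the step. The notes cannot say whether the change carries over between the two cores with the same size: the same change on two cores in this assay, a 1.1-fold higher number (0.03 log units; within the scatter) from compound 3 to compound 1 and an at least 1.9-fold lower number (0.29 log units; that floor lies within the scatter) from compound 2 to compound 4; the limit leaves it open whether they differ

Still open, as far as these compounds go, is how a piperidine or a morpholine would read in the same place on either core. Also open, from the compounds shown here alone, is what the change would do on a longer chain.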